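Swapping Chloro for Hydroxy on the Aromatic Carbon

The source may hold more compounds than are shown below. What is called first, only, known or untested is meant among the compounds shown, and "the series" means these compounds.

Measured so far:
compound 1, `O=C1/C(=C/c2cccc(C(F)(F)F)c2)CCc2cc(O)ccc21` — 180 nM
compound 2, `O=C1/C(=C/c2cccc(Cl)c2)CCc2cc(O)ccc21` — 1750 nM

In a functional assay on RAW264.7 cells (Mus musculus) for inhibition (a higher number here means a weaker inhibitor, a lower number a stronger inhibitor), compound 1 gives 180 nM. In this assay, among the compounds with values here, compound 2 gives 1750 nM, the highest of the two numbers known; its nearest neighbour is compound 1, and the single measured step is a 9.7-fold higher number from compound 1 to compound 2 (0.99 log units; beyond the scatter). Compound 3, `O=C1/C(=C/c2cccc(O)c2)CCc2cc(O)ccc21`, is the next member: hydroxy in place of chloro on an aromatic carbon.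

Within the data shown here, no measured step concerns hydroxy in place of chloro, so nothing in the data speaks directly to this change. Among the measured compounds shown here, the one step that exists, a 9.7-fold higher number from compound 1 to compound 2 (0.99 log units; beyond the scatter), involves a different pair of groups and shows only that a change at this position can shift the number beyond the scatter. For the measured compounds named here, with no bearing step, the estimate for compound 3 is held close to compound 2, without a firm direction, as a 1.4-fold higher number from compound 2 to compound 3 (0.15 log units; within the scatter). Compound 3 is therefore expected to give about 2500 nM, within a range from 500 nM to 12000 nM.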

Compound 3, half-maximal inhibitory concentration: 3510 nM
Compound 3: middle estimate off by 1.4-fold (0.15 log units), on the low side, and the stated range covers the measured number.
By their numbers in this assay, from the lowest: compound 1; then compounds 2 and 3 (each within the scatter of the next).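

In this assay, hydroxy in place of chloro on an aromatic carbon gives a 2.0-fold higher number from compound 2 to compound 3 (0.30 log units; within the scatter), so the two groups are not separated at this position, even though hydroxy brings a hydrogen-bond donor and a hydrogen-bond acceptor that chloro lacks. Trifluoromethyl now stands apart from both, with a 9.7-fold higher number from compound 1 to compound 2 (0.99 log units; beyond the scatter) and a 20-fold higher number from compound 1 to compound 3 (1.29 log units; beyond the scatter), which makes compound 1 the strongest inhibitor of the three. Nothing available explains why trifluoromethyl differs from the other two groups.

Three groups at one position cannot show whether this standing is particular to trifluoromethyl or shared by others, such as a nitrile, an amine or a carboxylic acid. The compounds shown also leave open what a methoxy group or a longer chain would do at this position.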